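A few compounds are considered here, and "the series" means these few. Any claim that something is new, unique, unknown or untested is made for them only; others in the source may bear on it.

Working notes on the series.

Three compounds share one core and differ only in the aryl on the ether oxygen. Compound 1 `CCCc1nc2ccccc2c(=O)n1/N=C/c1ccc(Oc2ccc3ccccc3c2)cc1` carries a naphthalen-2-yl there and in a physicochemical assay for lipophilicity, in phosphate buffer, measured as octanol-water partition (on this read-out lower numbers stand for lower lipophilicity and higher numbers for higher lipophilicity), compound 1 gives 6.12. Compound 2 `CCCc1nc2ccccc2c(=O)n1/N=C/c1ccc(Oc2ccc(F)cc2)cc1` carries a 4-fluorophenyl and in this assay compound 2 gives 5.22. Compound 3 `CCCc1nc2ccccc2c(=O)n1/N=C/c1ccc(Oc2ccc(C)cc2)cc1` carries a 4-methylphenyl and in this assay compound 3 gives 5.45.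

Compound 2 sits at the low end of these three numbers. The step of a number 0.90 log units lower from compound 1 to compound 2 (beyond the scatter) is beyond the scatter, as is a number 0.67 log units lower from compound 1 to compound 3 (beyond the scatter); by contrast a number 0.23 log units higher from compound 2 to compound 3 (within the scatter) is within the scatter, so compounds 2 and 3 cannot be told apart on this read-out.

Compound 4 `O=c1c2ccccc2nc(-c2ccccc2)n1/N=C/c1ccc(Oc2ccc(F)cc2)cc1` keeps the 4-fluorophenyl ether of compound 2 and changes the core instead: phenyl in place of propyl on an aromatic carbon. Among the measured compounds shown here, none of the measured steps touches this position; all three concern the aryl on the oxygen. For the measured compounds named here, the only guide is that the larger aryl of compound 1 gave the highest number, as a number 0.90 log units lower from compound 1 to compound 2 (beyond the scatter) shows, and the change here also adds ring carbons and removes a chain. A rise beyond the scatter, though not as large as that step, is expected for compound 4, a number 0.48 log units higher from compound 2 to compound 4 (beyond the scatter). The estimate for compound 4 is 5.7, expected between 5.3 and 6.1.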

Compound 4, partition coefficient: 6.21
The estimate for compound 4 lay 0.51 log units below the measured number; measured number outside the range, above it.
By their numbers in this assay, from the lowest: compounds 2 and 3 (each within the scatter of the next); then compounds 1 and 4 (each within the scatter of the next).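

Among the compounds shown here, the position between two ring nitrogen atoms on the shared core also moves this read-out: with phenyl in place of propyl, this assay shows a number 0.99 log units higher from compound 2 to compound 4 (beyond the scatter), so the aryl on the ether oxygen is no longer the only site with a step beyond the scatter. Neither group carries hydrogen-bond donors, hydrogen-bond acceptors or a net charge, so this step comes with no change in those counts, while the open propyl chain gives way to a six-membered aromatic ring of carbon only. Nothing at hand explains the rise or separates the contribution of the ring from that of the added carbon atoms.

In the compounds shown, this position holds only propyl and phenyl, and the phenyl appears with the 4-fluorophenyl ether alone, so it remains open whether the step carries over to the 4-methylphenyl or naphthalen-2-yl ethers. Also open, going by these compounds, is where a longer alkyl chain, a saturated ring such as cyclohexyl, or a phenyl bearing an amine or a carboxylic acid would fall on this read-out.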